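Methoxyphenyl change from compound 2 to compound 3

The source may hold more compounds than are shown below. What is called first, only, known or untested is meant among the compounds shown, and "the series" means these compounds.

Going by the values given here, in a functional assay on the whole organism (strain Kunming) with Mus musculus as the target, with a stated time of 0.5 h (a higher number here means that more compound is needed for the effect, a lower number that less compound is needed), compound 2 (`COc1cccc(/C=C/C(=O)OC/C=C/c2cc(OC)c(OC)cc2OC)c1`) gives 643 umol/kg, the only number so far. Compound 1 (`COc1cc(OC)c(OC)cc1/C=C/COC(=O)/C=C/c1ccccc1C(F)(F)F`) gives > 473 umol/kg, which is a limit of the assay. Among the compounds with values here, the only measured step, a step that the limit leaves unreadable from compound 1 to compound 2, therefore gives no size to carry forward. Compound 3 (`COc1ccc(/C=C/C(=O)OC/C=C/c2cc(OC)c(OC)cc2OC)cc1`) differs from compound 2 as follows: 4-methoxyphenyl in place of 3-methoxyphenyl on a double-bonded chain carbon bound to a double-bonded chain carbon. With compound 2 at 643 umol/kg as the sole anchor, no step beyond the scatter is expected in this assay, and no direction is favoured. The expected change is a 1.0-fold lower number from compound 2 to compound 3 (0.02 log units; within the scatter). Compound 3 is estimated at 620 umol/kg, with an expected range of 260 umol/kg to 1400 umol/kg.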

Compound 3, dose for half-maximal effect: 634 umol/kg
Estimate against measurement, compound 3: 1.0-fold (0.01 log units) below; the range from low to high includes it.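

In this assay, going by these compounds alone, exchanging 3-methoxyphenyl for 4-methoxyphenyl at this place gives the first readable step, a 1.0-fold lower number from compound 2 to compound 3 (0.01 log units; within the scatter), so the two methoxyphenyl groups are not told apart here. The steps from compound 1 to compound 2 and to compound 3 cannot be read, because the value of compound 1 is a limit of the assay: the limit of > 473 umol/kg in this assay, at which 1 of the 3 values shown sits.

From the compounds shown here alone, whether 2-(trifluoromethyl)phenyl differs from either methoxyphenyl group remains open. Also open, going by these compounds, is whether a phenyl group carrying an amine or a carboxylic acid at this place would shift the number beyond the scatter.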